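This account rests on a few compounds, and the source may have more. Where it says the series, first, only, none or still open, it means among the compounds named here.

Measured so far in a functional assay on the whole organism (strain Wistar) for inhibition, with Rattus norvegicus as the target, read by paw edema, with a stated time of 30 min, at a dose of 10 mg/kg by the intraperitoneal route; a higher number here means more inhibition at the dose given (going by the name of the read-out), a lower number less inhibition:
- compound 1, `O=C(N/N=C/c1cccc(F)c1)c1cccnc1Nc1cccc(C(F)(F)F)c1`: compound 1 gives 58.3%
- compound 2, `O=C(N/N=C/c1cccc(O)c1)c1cccnc1Nc1cccc(C(F)(F)F)c1`: compound 2 gives 67.5%
- compound 3, `O=C(N/N=C/c1ccc(O)c(O)c1)c1cccnc1Nc1cccc(C(F)(F)F)c1`: compound 3 gives 51.4%

Compound 3 stands at the low end of these three numbers. Against compound 2 the gap is real, a number 16.1 percentage points lower from compound 2 to compound 3 (beyond the scatter); against compound 1 it is not, a number 6.9 percentage points lower from compound 1 to compound 3 (within the scatter). The step of a number 9.2 percentage points higher from compound 1 to compound 2 (within the scatter) also stays within the scatter, so only the hydroxy-for-hydrogen step has moved this assay at all.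

Compound 4, `COc1ccc(/C=N/NC(=O)c2cccnc2Nc2cccc(C(F)(F)F)c2)cc1OC`, has not been measured. Its change from compound 3 is 3,4-dimethoxyphenyl in place of 3,4-dihydroxyphenyl on a carbon with a double bond to nitrogen.

Going by the values given here, the steps that bear on it are those at the same carbon: compound 1 to compound 3 (within the scatter) and compound 2 to compound 3 (modest, beyond the scatter). Among the compounds with values here, no measured step swaps hydroxy for methoxy, so the direction is not fixed by the data. Replacing both hydroxy groups is expected to move compound 4 back into the span of compounds 1 and 2, giving an expected step of a number 4.6 percentage points higher from compound 3 to compound 4 (within the scatter), probably not beyond the scatter. Compound 4 is therefore estimated at 56%, with a range of 43% to 69%.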

Compound 4, a percentage reported as inhibition, in the whole organism at one dose (the size of the read-out at that dose, not a potency): 60.1%
Compound 4: the middle estimate sits 4.1 percentage points below what was measured; the range from low to high includes it.
By their numbers in this assay, from the lowest: compounds 3, 1, 4 and 2 (each within the scatter of the next, the first and the last beyond it).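

In this assay, 3,4-dimethoxyphenyl in place of the earlier groups on a carbon with a double bond to nitrogen reads as a number 8.7 percentage points higher from compound 3 to compound 4 (within the scatter) and as a number 7.4 percentage points lower from compound 2 to compound 4 (within the scatter) and as a number 1.8 percentage points higher from compound 1 to compound 4 (within the scatter) at this single dose. Going by these compounds alone, this position therefore carries a larger group with 0 hydrogen-bond donors, and the first comparison of methoxy with hydroxy here gives no step beyond the scatter against any earlier compound. No measured property of these compounds is available to account for these numbers.

From the compounds shown here alone, whether an amine or a carboxylic acid on this aromatic ring, or a longer chain in place of methoxy, would keep the read-out remains open. The compounds shown also share one core, so they say nothing about changes elsewhere in it.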